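A bromo in place of chloro on compound 2

The source may report more compounds than this note shows. Statements on the series, on what has been measured and on what is new or still open speak of the compounds shown alone.

In an ADME assay on RAW264.7 cells (Mus musculus) for cytotoxicity, read by MTT assay, with a stated time of 48 h (a lower number here means that less compound is tolerated, a higher number that more compound is tolerated), compound 2 `C#CCN(c1nc(-c2ccc(Cl)cc2)no1)C1CCCCC1` gives 15.1 ug/mL. Compound 3 `CCCCCCCCCCc1cn(C[C@@H](CO[C@@H]2C=C[C@H](OC(C)=O)[C@@H](COC(C)=O)O2)OC(C)=O)nn1` gives 30.4 ug/mL, which lies within the usual scatter of compound 2. Compound 1 `CC(=O)OC[C@H]1O[C@H](OC[C@@H](Cn2cc(CN(c3nc(-c4ccc(Cl)cc4)no3)C3CCCCC3)nn2)OC(C)=O)C=C[C@@H]1OC(C)=O` gives 35.5 ug/mL, a higher number that lies beyond the scatter of compound 2. Compound 4 `C#CCN(c1nc(-c2ccc(Br)cc2)no1)C1CCCCC1` differs from compound 2 in one place: bromo in place of chloro on an aromatic carbon. Among the compounds with values here, no two measured compounds differ in only one place, so the data offer no direct guide to this change. The expectation therefore rests on compound 2 at 15.1 ug/mL. In this assay, the step of a 1.0-fold lower number from compound 2 to compound 4 (0.00 log units; within the scatter) is expected to stay within the scatter, in neither direction. The estimate for compound 4 is 15 ug/mL, with an expected range of 8 ug/mL to 28 ug/mL.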

Compound 4, half-maximal cytotoxic concentration: 15.7 ug/mL
Beside the measured number, compound 4's estimate is 1.0-fold (0.02 log units) below it; the measured number falls inside the stated range.
By their numbers in this assay, from the lowest: compounds 2, 4, 3 and 1 (each within the scatter of the next, the first and the last beyond it).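

In this assay, bromo in place of chloro on the aromatic carbon para to a large group gives a 1.0-fold higher number from compound 2 to compound 4 (0.02 log units; within the scatter) and is the only comparison among these compounds that differs in one place. It shows that this read-out does not separate 4-chlorophenyl from 4-bromophenyl on this scaffold. Nothing shown offers an explanation for this result.

On these data alone, whether an amine, a methoxy group or a carboxylic acid at this position would shift the number beyond the scatter remains open. So does whether the same exchange would read alike on compound 1.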